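A few compounds are considered here, and "the series" means these few. Any claim that something is new, unique, unknown or untested is made for them only; others in the source may bear on it.

Measured in a functional assay on NAMALVA cells (Homo sapiens) for cytotoxicity, read by MTT assay, with a stated time of 72 h; a lower number here means a stronger inhibitor, a higher number a weaker inhibitor:
- Compound 1 `O=C(Nc1ccccc1)Nc1ccc(C(=O)NO)cc1`: 530 nM
- Compound 2 `O=C(Nc1ccc(Cl)cc1)Nc1ccc(C(=O)NO)cc1`: 870 nM
- Compound 3 `O=C(CCc1ccc(NC(=O)Nc2ccccc2)cc1)NO`: 780 nM

All three values lie within the usual scatter of one another, so compound 3 cannot be ranked against compound 1 or compound 2. Compound 4 `O=C(CCc1ccc(NC(=O)Nc2ccc(Cl)cc2)cc1)NO` differs from compound 3 by chloro in place of hydrogen on an aromatic carbon, para to a large group, which turns phenyl into 4-chlorophenyl (chloro in place of hydrogen on an aromatic carbon). The same change has been measured once, on another core, as a 1.6-fold higher number from compound 1 to compound 2 (0.22 log units; within the scatter). The step that links those two cores, a 1.5-fold higher number from compound 1 to compound 3 (0.17 log units; within the scatter), is also small. The expected result in this assay is a 1.3-fold higher number from compound 3 to compound 4 (0.11 log units; within the scatter), so at most a slight rise, not expected to exceed the scatter. Compound 4 is estimated at 1000 nM, with an expected range from 450 nM to 2200 nM.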

Compound 4, half-maximal inhibitory concentration: 370 nM
Compound 4: middle estimate off by 2.7-fold (0.43 log units), on the high side; the whole stated range lies above it.
By their numbers in this assay, from the lowest: compounds 4, 1, 3 and 2 (each within the scatter of the next, the first and the last beyond it).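

In this assay, going by these compounds alone, putting chloro para to a large group has no fixed effect: on the core of compound 3, phenyl to 4-chlorophenyl gives a 2.1-fold lower number from compound 3 to compound 4 (0.32 log units; beyond the scatter), the first step here beyond the scatter. The same change behaves differently on the two cores: the same change on two cores in this assay, a 1.6-fold higher number (0.22 log units; within the scatter) from compound 1 to compound 2 and a 2.1-fold lower number (0.32 log units; beyond the scatter) from compound 3 to compound 4, 3.5-fold (0.54 log units) apart, beyond the scatter of two such steps Swapping hydroxycarbamoyl for 2-(hydroxycarbamoyl)ethyl likewise depends on what else is present, giving a 2.4-fold lower number from compound 2 to compound 4 (0.37 log units; beyond the scatter) when the chloro is there: the same change on two cores in this assay, a 1.5-fold higher number (0.17 log units; within the scatter) from compound 1 to compound 3 and a 2.4-fold lower number (0.37 log units; beyond the scatter) from compound 2 to compound 4, 3.5-fold (0.54 log units) apart, beyond the scatter of two such steps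

Within the data shown here, each core has only one such pair, so it remains open whether another group at this place, such as fluoro, methoxy or an amine, would follow chloro. On these data alone, it is also open how a longer chain carrying the hydroxycarbamoyl would behave.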